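Cytotoxicity notes: methylsulfonyl in place of cyclopropylcarbamoyl

The source may report more compounds than this note shows. Statements on the series, on what has been measured and on what is new or still open speak of the compounds shown alone.

In an ADME assay on HeLa cells (Homo sapiens) for cytotoxicity, read by ATP content, with a stated time of 3 days (a higher number here means that more compound is tolerated, a lower number that less compound is tolerated), compound 1 `CS(=O)(=O)CCCn1c(Cn2c(=O)n(C3CC3)c3ccncc32)nc2nc(Cl)ccc21` gives > 50000 nM, which is a limit of the assay and not a number. Compound 3 `CC(C)CCn1c(Cn2c(=O)n(C3CC3)c3ccncc32)nc2ccncc21` gives > 100000 nM in this assay, likewise a limit. Compound 2 `N#CCCCn1c(Cn2c(=O)n(-c3ccc(C(=O)NC4CC4)cc3)c3ccncc32)cc2cc(Cl)ccc21` gives > 50000 nM in this assay, again a limit rather than a number. Compound 2 thus stands among values that are all limits; the values shown fall at the limit of > 50000 nM in this assay, at which 2 of the 3 values shown sit, and at the limit of > 100000 nM in this assay, at which 1 of the 3 values shown sits, so no order among the three compounds can be read from them. Compound 4 `CS(=O)(=O)c1ccc(-n2c(=O)n(Cc3cc4cc(Cl)ccc4n3CCCC#N)c3cnccc32)cc1` is not yet measured in this assay. It differs from compound 2 by methylsulfonyl in place of cyclopropylcarbamoyl on an aromatic carbon. Among the measured compounds shown here, no step between measured compounds is available here to rest a comparison on. With every measured value a limit, the expectation for compound 4 in this assay is no step beyond the scatter, and most probably a limit once more. The estimate for compound 4 is 80000 nM, with a range from 40000 nM to 200000 nM. The expected step is a step that the limit leaves unreadable from compound 2 to compound 4, within the scatter.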

Compound 4, half-maximal cytotoxic concentration: > 50000 nM
Compound 4 ended at the assay's limit; the forecaster's own chance of this, stated with the estimate: 85%; the middle value is on the limit's open side.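

Compound 2 and compound 4 both end at a limit rather than a number in this assay, so no new step can be read between them: the limit of > 50000 nM in this assay, at which 3 of the 4 values shown sit.

The compounds shown leave open what methylsulfonyl in place of cyclopropylcarbamoyl does to the half-maximal cytotoxic concentration, and where any of these compounds would give a number.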